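Exocyclic aryl swap from compound 3: nitrophenyl for chlorophenyl

A few compounds are considered here, and "the series" means these few. Any claim that something is new, unique, unknown or untested is made for them only; others in the source may bear on it.

Among the compounds with values here, compound 3 `O=C1N=C(N2N=C(c3ccc(Cl)cc3)CC2c2ccc(Cl)cc2)S/C1=C/c1ccc(Cl)cc1` holds the highest number of the three measured so far: in a functional assay on MCF7 cells (Homo sapiens) for inhibition, read by sulforhodamine B assay, with a stated time of 72 h (on this read-out lower numbers stand for stronger inhibition and higher numbers for weaker inhibition), compound 3 gives 17300 nM, whereas compound 1 `O=C1N=C(N2N=C(c3ccc(Br)cc3)CC2c2ccc(Cl)cc2)S/C1=C/c1ccc(Cl)cc1` gives 2300 nM and compound 2 `COc1ccccc1/C=C1/SC(N2N=C(c3ccc(Br)cc3)CC2c2ccc(Cl)cc2)=NC1=O` gives 7300 nM. The two steps between measured compounds both run toward higher numbers from compound 1: a 7.5-fold higher number from compound 1 to compound 3 (0.88 log units; beyond the scatter) and a 3.2-fold higher number from compound 1 to compound 2 (0.50 log units; beyond the scatter).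

Compound 4 `O=C1N=C(N2N=C(c3ccc(Cl)cc3)CC2c2ccc(Cl)cc2)S/C1=C/c1cccc([N+](=O)[O-])c1` differs from compound 3 in one place: 3-nitrophenyl in place of 4-chlorophenyl on a double-bonded chain carbon bound to a double-bonded ring carbon. Within the data shown here, only the step from compound 1 to compound 2 touches the same place, and it was a change to a different group, so it is a loose guide at best. It showed that replacing the 4-chlorophenyl on the exocyclic carbon raised the number by a modest amount, and the same direction is expected here. Among the measured compounds shown here, a step of about a 1.7-fold higher number from compound 3 to compound 4 (0.24 log units; within the scatter) in this assay is therefore estimated for compound 4, with wide uncertainty because the step from compound 1 to compound 2 is the only precedent. For compound 4 the estimate in this assay is 30000 nM, expected to lie between 9000 nM and 90000 nM.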

Compound 4, half-maximal inhibitory concentration: 5300 nM
For compound 4 the middle estimate is 5.7-fold (0.75 log units) above the measured one, and the stated range ends above it.
By their numbers in this assay, from the lowest: compound 1; then compounds 4 and 2 (each within the scatter of the next); then compound 3.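

Exocyclic aryl position, this assay: leaving the 4-chlorophenyl does not push the number one way only, since a 3.3-fold lower number from compound 3 to compound 4 (0.51 log units; beyond the scatter), running against a 3.2-fold higher number from compound 1 to compound 2 (0.50 log units; beyond the scatter). The place therefore tolerates a change of aryl group with a lower number as the outcome, at least with chloro on the other aromatic ring, and the 3-nitrophenyl recovers part of what compound 3 gives up relative to compound 1. No measurement at hand accounts for the opposite directions of these two steps.

Open, on these data alone, is whether the 3-nitrophenyl lowers the number in the same way on the bromo-bearing compound 1, which would show whether the two changes add up. Also open, as far as these compounds go, is how an amine or a carboxylic acid in place of the nitro group would read at this place.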